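The source may report more compounds than this note shows. Statements on the series, on what has been measured and on what is new or still open speak of the compounds shown alone.

Compound 1 `CCNC(=O)c1sc(-c2ccccc2)nc1O`: > 100000 nM
Compound 2 `CCOC(=O)c1sc(-c2ccc(C)cc2)nc1O`: 160 nM

Going by the values given here, in an assay on HEK293 cells for inhibition of transient receptor potential cation channel subfamily M member 8 (Homo sapiens), read by FLIPR, with stated times of 5 min and 3 min (on this read-out higher numbers stand for weaker inhibition and lower numbers for stronger inhibition), compound 2 gives 160 nM, the only actual number among the two values shown. Compound 1 gives > 100000 nM, which is a limit of the assay and not a number (the limit of > 100000 nM in this assay, at which 1 of the 2 values shown sits). Among the compounds with values here, compound 2 therefore stands alone as the one compound with a measured potency, and no step between two measured compounds is available to calibrate the next change.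

Compound 3 `CCOC(=O)c1sc(-c2ccc(Cl)cc2)nc1O` differs from compound 2 by chloro in place of methyl on an aromatic carbon. Within the data shown here, with no measured step of this kind to lean on, the expected change is small: the step from compound 2 to compound 3 is estimated to lie within the usual scatter, leaning if anything toward slightly stronger inhibition. The expected step is a 1.3-fold lower number from compound 2 to compound 3 (0.12 log units; within the scatter). Compound 3 is thus estimated at 120 nM in this assay, in a range from 40 nM to 400 nM.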

Compound 3, half-maximal inhibitory concentration: 550 nM
For compound 3 the middle estimate is 4.6-fold (0.66 log units) below the measured one; the measured number lies above the stated range.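

In this assay, exchanging methyl for chloro on an aromatic carbon, para to a large group, gives a 3.4-fold higher number from compound 2 to compound 3 (0.54 log units; beyond the scatter). Going by these compounds alone, this is the first measured change at this position, and it shows that the position responds to the swap of one heavy atom for another, even though neither group brings hydrogen-bond donors, acceptors or a net charge, with methyl giving the stronger inhibition of the two. Nothing measured here bears on why this exchange weakens inhibition.

As far as these compounds go, whether fluoro, methoxy or trifluoromethyl at this position would behave more like methyl or more like chloro remains open. From the compounds shown here alone, the role of the ethyl ester also remains open, as compound 1, with its ethyl amide, differs from compound 2 in more than one place.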